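The source may report more compounds than this note shows. Statements on the series, on what has been measured and on what is new or still open speak of the compounds shown alone.

Compound 1 `CCCCN(C)CCCCC(=O)N(O)CCC(=O)O`: 4300 nM
Compound 2 `CN(C)CCCCC(=O)N(O)CCC(=O)O`: 18000 nM

In an assay on isolated protein for inhibition of lysine-specific demethylase 5A (Homo sapiens), with a stated time of 60 min (a higher number here means a weaker inhibitor, a lower number a stronger inhibitor), compound 2 gives the highest of the two numbers; its nearest neighbour is compound 1, which gives a lower number. Among the compounds with values here, the only measured step, a 4.2-fold higher number from compound 1 to compound 2 (0.62 log units; beyond the scatter), was a modest rise in the number. Compound 3 `CCCN(C)CCCCC(=O)N(O)CCC(=O)O` differs from compound 2 by ethyl in place of hydrogen on a saturated chain carbon bound to an amine nitrogen, that is, methyl to propyl on the amine. Compound 3 thus sits part of the way back toward compound 1 in chain length, so for compound 3 a drop in the number is expected, about a 2.8-fold lower number from compound 2 to compound 3 (0.44 log units; beyond the scatter). For compound 3 the value is estimated at 6500 nM, within 2500 nM to 15000 nM.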

Compound 3, half-maximal inhibitory concentration: 8900 nM
Compound 3: middle estimate off by 1.4-fold (0.14 log units), on the low side; low and high end bracket the measured number.
By their numbers in this assay, from the lowest: compound 1; then compound 3; then compound 2.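

Growing the chain on the amine from methyl to propyl already lowers the number (a 2.0-fold lower number from compound 2 to compound 3 (0.31 log units; beyond the scatter)), and the final stretch of chain still counts (a 2.1-fold higher number from compound 1 to compound 3 (0.32 log units; beyond the scatter)). In this assay the number therefore falls in two similar stages across these three compounds, with none going against this order. Nothing at hand explains this trend.

On these data alone, whether a longer chain such as pentyl or hexyl would lower the number further remains open. So does whether a benzyl group on the amine would do the same.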